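Removing one methoxy group from the aryl ring of compound 1

The compounds below may be only part of what the source reports. "The series", "measured", "known", "first", "only" and "open" are said of these compounds alone.

Measured compounds:
compound 1, `COc1cc(-c2cc(/C=C/C(=O)c3ccc(N)cc3)[nH]n2)cc(OC)c1OC`: -91%
compound 2, `COc1cc(-c2cc(/C=C/C(=O)c3ccc(Cl)c(Cl)c3)[nH]n2)cc(OC)c1OC`: -50%

In a functional assay on HCC 2998 cells (Homo sapiens) for cytotoxicity, read by sulforhodamine B assay, with a stated time of 48 h, tested at 100 uM (on this read-out higher numbers stand for a weaker effect at the one concentration tested and lower numbers for a stronger effect), compound 1 gives -91%, the lowest of the two numbers; the nearest is compound 2, which gives -50% in this assay. Among the compounds with values here, the only measured step, a number 41 percentage points higher from compound 1 to compound 2 (beyond the scatter), comes from a 3,4-dichlorophenyl in place of a 4-aminophenyl on a carbonyl carbon, on the opposite side of the shared core from the change now considered.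

Compound 3, `COc1ccc(-c2cc(/C=C/C(=O)c3ccc(N)cc3)[nH]n2)cc1OC`, differs from compound 1 by hydrogen in place of methoxy on an aromatic carbon. Within the data shown here, no measured step touches this part of the molecule, so nothing in the data speaks directly to the size or direction of the step from compound 1 to compound 3 in this assay. The account therefore starts from the value of compound 1, -91%, and allows a modest move toward a higher number, keeping the step near the scatter of repeated measurements.

Compound 3 is expected to give about -75% in this assay, within a range from -100% to -35%. This estimate means a step of a number 16 percentage points higher from compound 1 to compound 3 (beyond the scatter), which is expected to be small.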

Compound 3, a percentage reported as activity, at one concentration (the size of the read-out at that concentration, not a potency): -91%
The estimate for compound 3 lay 16 percentage points above the measured number; measured number inside the range.
By their numbers in this assay, from the lowest: compounds 1 and 3 (each within the scatter of the next); then compound 2.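

In this assay, hydrogen in place of methoxy gives no change at the digits printed from compound 1 to compound 3 (within the scatter), so losing this methoxy, ortho to a methoxy group and meta to a large group, moves the read-out by nothing beyond the scatter. Set beside a number 41 percentage points higher from compound 1 to compound 2 (beyond the scatter), a change on the other side of the shared core, this shows that among these three compounds the read-out responds to the change at the carbonyl carbon and not to the change on this aromatic carbon. Nothing measured here accounts for this result.

Going by these compounds, it stays open whether this aromatic carbon would read the same with other groups in place of the methoxy, such as a hydroxyl, a fluorine or an ethoxy chain, and whether removing either remaining methoxy group would also leave the number where it stands. On these data alone, it is equally open whether hydrogen in place of methoxy would read the same with the 3,4-dichlorophenyl on the carbonyl carbon, as in compound 2, which gives -50%.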